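The source may hold more compounds than are shown below. What is called first, only, known or untested is meant among the compounds shown, and "the series" means these compounds.

Measured compounds:
Compound 1, `C=C[C@@]1(C)C=C(C)[C@@H]2[C@@H]3[C@H](Oc4ccc(cc4)C[C@@H]4C(=O)NC(=O)[C@@H]4C(=O)[C@H]31)[C@@H]1[C@@H](C)C[C@@H](C)C[C@]12C`, gives 8100 nM in an assay on isolated protein for inhibition of receptor-type tyrosine-protein phosphatase C (Homo sapiens); a lower number here means a stronger inhibitor, a higher number a weaker inhibitor.
Compound 2, `CO[C@@]12Cc3ccc(cc3)O[C@H]3[C@H]([C@H]4C(=O)[C@](C[C@@H](O)[C@]4(C)C=O)(C1)C(=O)N2)[C@@H](C(C)=O)[C@]1(C)C[C@H](C)C[C@H](C)[C@@H]31`, reaches only the limit of this assay, > 200000 nM.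

The account follows the step from compound 2 to compound 3, `CC(=O)[C@@H]1[C@@H]2[C@H](Oc3ccc(cc3)C[C@]3(O)C[C@]4(C[C@@H](O)[C@](C)(C=O)[C@@H]2C4=O)C(=O)N3)[C@@H]2[C@@H](C)C[C@@H](C)C[C@]21C`. Compound 2 stands at the weaker end of what has been measured: its value in this assay is a limit and not a number, and it sits at the limit of > 200000 nM in this assay, at which 1 of the 2 values shown sits. For the measured compounds named here, compound 1 is the only compound with a measured number. The change is hydrogen in place of methyl on an oxygen on a saturated carbon, or read one bond further out, methoxy to hydroxy. Going by the values given here, no measured step of this kind exists here, so the direction of the step in this assay cannot be read from the measured pair. The step of a number no higher from compound 2 to compound 3 (the limit leaves the size open) is estimated to lie within the scatter, in no particular direction. Compound 3 is therefore expected to give about 200000 nM, within a range from 50000 nM to 600000 nM, most likely again only as a limit.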

Compound 3, half-maximal inhibitory concentration: > 200000 nM
Compound 3 was reported as a limit; the forecaster's own chance of this, stated with the estimate: 75%; the middle value sits exactly at the limit.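

For the compounds shown here, neither compound 2 nor compound 3 gives a number, only a limit, so no step between them can be read: the limit of > 200000 nM in this assay, at which 2 of the 3 values shown sit. The compounds shown leave open whether methoxy to hydroxy changes anything in this assay when the compound gives a measured number.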